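A Prodrug Ester Change Tested Against a Ceiling

The source may report more compounds than this note shows. Statements on the series, on what has been measured and on what is new or still open speak of the compounds shown alone.

Compound 3 (`C[C@@H](O)[C@H]1C(=O)N2C(C(=O)OCC(F)(F)F)=C(S[C@@H]3CN[C@H](C(=O)Nc4cccc(C(=O)O)c4)C3)[C@H](C)[C@H]12`) stands at a limit rather than at a number: in an ADME assay for metabolic stability, read by LC-MS, with a stated time of 3 h, at pH 6.5, tested at 50 uM (a higher number here means that more of the compound is left, a lower number that less of the compound is left), compound 3 gives > 95%. Compound 1 (`CCOC(=O)C1=C(S[C@@H]2CN[C@H](C(=O)Nc3cccc(C(=O)O)c3)C2)[C@H](C)[C@@H]2[C@@H]([C@@H](C)O)C(=O)N12`) gives > 95% in this assay, which is again a limit. Compound 2 (`CC(C)OC(=O)OCOC(=O)C1=C(S[C@@H]2CN[C@H](C(=O)Nc3cccc(C(=O)O)c3)C2)[C@H](C)[C@@H]2[C@@H]([C@@H](C)O)C(=O)N12`) gives > 95% in this assay, also a limit. Because all three values sit at the limit of > 95% in this assay, at which 3 of the 3 values shown sit, none of the steps among these compounds can be read: a step that the two limits leave unreadable from compound 1 to compound 2, a step that the two limits leave unreadable from compound 1 to compound 3 and a step that the two limits leave unreadable from compound 2 to compound 3.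

Compound 4 (`CCC(CC)C(=O)OCOC(=O)C1=C(S[C@@H]2CN[C@H](C(=O)Nc3cccc(C(=O)O)c3)C2)[C@H](C)[C@@H]2[C@@H]([C@@H](C)O)C(=O)N12`) differs from compound 3 in a single place: ((pentan-3-yl)carbonyl)oxy in place of trifluoromethyl on a saturated chain carbon bound to an oxygen next to a carbonyl group. The measured steps that bear on this change are the three just named, and each of them is left unreadable by the limits, so they give no size and no direction. What they do show is that compound 2, which carries (isopropoxycarbonyl)oxy on a saturated chain carbon bound to an oxygen next to a carbonyl group, sits at the same limit as the other two.

On that basis no step beyond the scatter is expected in this assay, and the estimated step is a number at least 2 percentage points lower from compound 3 to compound 4 (that floor lies within the scatter). Compound 4 is estimated at 93%, with a range from 78% to 100%.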

Compound 4, percent of the compound remaining: > 95%
Compound 4: a limit, no number; the forecaster's own chance of this, stated with the estimate: 60%; at least 2 percentage points between middle value and limit.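

In this assay compound 4 gives > 95%, which is a limit and not a number. No new step from compound 1, compound 2 or compound 3 to compound 4 can be read, because all four values share one limit: the limit of > 95% in this assay, at which 4 of the 4 values shown sit.

The compounds shown leave open how much of each compound actually remains in this assay, and whether the four differ at all.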